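The source may report more compounds than this note shows. Statements on the series, on what has been measured and on what is new or still open speak of the compounds shown alone.

Measured so far in an assay on COS-7 cells for displacement of a labelled ligand from Endothelin receptor type B (Sus scrofa); a higher number here means a weaker inhibitor, a lower number a stronger inhibitor:
- compound 1, `COC(=O)CCCc1onc(NS(=O)(=O)c2ccc(C(C)(C)C)cc2)c1Sc1cccc(OC)c1`, gives 310 nM
- compound 2, `CCc1onc(NS(=O)(=O)c2ccc(C(C)(C)C)cc2)c1Sc1cccc(OC)c1`, gives 2800 nM
- compound 3, `COc1cccc(Sc2c(NS(=O)(=O)c3ccc(C(C)(C)C)cc3)noc2CCCC#N)c1`, gives 520 nM

Compound 3 holds the second highest of the three numbers. Its nearest neighbour is compound 1, the pair being separated by a 1.7-fold higher number from compound 1 to compound 3 (0.22 log units; within the scatter); the furthest is compound 2, separated by a 5.4-fold lower number from compound 2 to compound 3 (0.73 log units; beyond the scatter).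

Compound 4, `COc1cccc(Sc2c(NS(=O)(=O)c3ccc(C(C)(C)C)cc3)noc2CCCCC=O)c1`, is the next member. Relative to compound 3 it carries formylmethyl in place of cyano on a saturated chain carbon, three bonds along the chain from an aromatic carbon.

Two kinds of measured step bear on this. The exchange of one chain-end acceptor for another, a 1.7-fold higher number from compound 1 to compound 3 (0.22 log units; within the scatter), stayed within the scatter. Removing or adding the chain end wholesale, a 9.0-fold higher number from compound 1 to compound 2 (0.96 log units; beyond the scatter) and a 5.4-fold lower number from compound 2 to compound 3 (0.73 log units; beyond the scatter), gave modest shifts. Compound 4 retains a chain end bearing one hydrogen-bond acceptor, so the change from compound 3 is of the first kind, and no step beyond the scatter is expected in this assay: a 1.2-fold lower number from compound 3 to compound 4 (0.06 log units; within the scatter).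

For compound 4 the expected value is therefore 450 nM, with a range from 160 nM to 1300 nM.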

Compound 4, half-maximal inhibitory concentration: 20 nM
Compound 4: middle estimate off by 23-fold (1.35 log units), on the high side; measured number below the stated range.
By their numbers in this assay, from the lowest: compound 4; then compounds 1 and 3 (each within the scatter of the next); then compound 2.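

In this assay holding a chain-end acceptor is not enough to set the number at this position: going from 3-cyanopropyl to 4-formylbutyl gives a 26-fold lower number from compound 3 to compound 4 (1.41 log units; beyond the scatter) although both groups count one hydrogen-bond acceptor and no donor, while the earlier exchange of methoxycarbonyl for cyano gave only a 1.7-fold higher number from compound 1 to compound 3 (0.22 log units; within the scatter). The 4-formylbutyl end also stands apart from the methoxycarbonyl end, with a 16-fold lower number from compound 1 to compound 4 (1.19 log units; beyond the scatter) and from the short chain, with a 140-fold lower number from compound 2 to compound 4 (2.15 log units; beyond the scatter) and so gives the lowest number of the four, with all its steps beyond the scatter. Nothing available explains why the formyl end differs so sharply from the other chain ends.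

The step changes the end group and the chain length together, so the share of each remains unresolved. A 4-cyanobutyl chain, or a hydroxyl or carboxylic acid at the end of the same chain, would help to separate them.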